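This account rests on a few compounds, and the source may have more. Where it says the series, first, only, none or still open, it means among the compounds named here.

Measured compounds:
compound 1 `CC1(C)[C@H]2CC[C@]1(C)N(Cc1cn(-c3ccccc3Cl)nn1)C(=O)C2` — 60 nM
compound 2 `CC1(C)[C@H]2CC[C@]1(C)N(Cc1cn(-c3cccc(Cl)c3)nn1)C(=O)C2` — 60 nM

In a functional assay on HepG2 cells (Homo sapiens) for inhibition, read by MTT assay, with a stated time of 24 h (on this read-out higher numbers stand for weaker inhibition and lower numbers for stronger inhibition), compound 1 gives 60 nM and stands level with compound 2 at the digits recorded, because no change at the digits printed from compound 1 to compound 2 (within the scatter). Compound 3 `COc1cccc(-n2cc(CN3C(=O)C[C@@H]4CC[C@@]3(C)C4(C)C)nn2)c1` differs from compound 1 thus: 3-methoxyphenyl in place of 2-chlorophenyl on an aromatic nitrogen. Among the measured compounds shown here, the one measured step at this position, no change at the digits printed from compound 1 to compound 2 (within the scatter), swaps 2-chlorophenyl for 3-chlorophenyl on an aromatic nitrogen without effect beyond the scatter. For the measured compounds named here, no measured compound carries a methoxyphenyl group, so that part of the change is untested. For compound 3 a step of no change at the digits printed from compound 1 to compound 3 (within the scatter) is expected, nothing beyond the scatter. Compound 3 is estimated at 60 nM, range 30 nM to 130 nM.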

Compound 3, half-maximal inhibitory concentration: 70 nM
For compound 3 the middle estimate is 1.2-fold (0.07 log units) below the measured one; the measured number falls inside the stated range.
By their numbers in this assay, from the lowest: compounds 1, 2 and 3 (each within the scatter of the next).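

In this assay, 3-methoxyphenyl in place of 2-chlorophenyl on the aromatic nitrogen gives a 1.2-fold higher number from compound 1 to compound 3 (0.07 log units; within the scatter), and methoxy in place of chloro on the aromatic carbon gives a 1.2-fold higher number from compound 2 to compound 3 (0.07 log units; within the scatter). The position therefore accepts an oxygen-bearing group as well as chloro, with no shift beyond the scatter. No data are available that bear on the reason for this result.

Going by these compounds, whether the response stays this flat with an amine, a carboxylic acid or a longer chain on the phenyl ring remains open. Unsubstituted phenyl also remains open.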